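Working notes: from compound 1 to compound 3

This account rests on a few compounds, and the source may have more. Where it says the series, first, only, none or still open, it means among the compounds named here.

Measured in a functional assay on A2780 cells (Homo sapiens) for antiproliferative activity; a lower number here means a stronger inhibitor, a higher number a weaker inhibitor:
- compound 1 `COc1cc(/C=C\Cc2cc(O)c3ccsc3c2)cc(OC)c1OC`: 95 nM
- compound 2 `COc1cc(/C=C\Cc2cc(O)c3ccoc3c2)cc(OC)c1OC`: 46 nM

Compound 1 holds the higher of the two numbers, and compound 2 lies below it by slightly more than the usual scatter. Compound 3 `COc1cc(/C=C\Cc2cc(OP(=O)(O)O)c3ccsc3c2)cc(OC)c1OC` differs from compound 1 in one place, on an oxygen on an aromatic ring: a group of 4 heavy atoms (3 oxygen, 1 phosphorus; no ring) in place of a hydrogen atom, on an oxygen on an aromatic ring. Going by the values given here, no measured pair covers this change, so its size remains uncertain. A moderate rise in this assay, towards weaker inhibition, is expected. The expected step is a 1.8-fold higher number from compound 1 to compound 3 (0.25 log units; within the scatter). For compound 3 the estimated value is 170 nM, with an expected range of 40 nM to 800 nM.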

Compound 3, half-maximal inhibitory concentration: 750 nM
Compound 3: the middle estimate sits 4.4-fold (0.64 log units) below what was measured, within the range that was stated.
By their numbers in this assay, from the lowest: compound 2; then compound 1; then compound 3.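

Going by these compounds alone, the step at this oxygen on an aromatic ring is the first reading of any change there: in this assay, the group of 4 heavy atoms in place of the hydrogen gives a 7.9-fold higher number from compound 1 to compound 3 (0.90 log units; beyond the scatter). The hydrogen on this oxygen therefore cannot be exchanged for this group without a loss beyond the scatter, though compound 3 keeps measurable antiproliferative activity. Nothing available bears on the reason for this loss. Open, on these data alone, is whether a methyl ether or an acetyl ester on the same oxygen would give a smaller step. Also open, as far as these compounds go, is whether the same exchange on compound 2 would give a step of similar size.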